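The source may hold more compounds than are shown below. What is called first, only, known or untested is meant among the compounds shown, and "the series" means these compounds.

The measured compounds:
Compound 1, `C=C(C)[C@@H]1CC=C(Cn2cc(COc3cccc(C4NC(=O)NC(C)=C4C(=O)OCC)c3)nn2)CC1`, gives 42500 nM.
Compound 2, `C=C(C)[C@@H]1CC=C(Cn2cc(COc3cc(C4NC(=O)NC(C)=C4C(=O)OCC)ccc3OC)nn2)CC1`, gives > 100000 nM.

Compound 1 holds the only number shown in a functional assay on MCF7 cells (Homo sapiens) for inhibition, read by sulforhodamine B assay, with a stated time of 48 h; a lower number here means a stronger inhibitor of growth, a higher number a weaker inhibitor of growth. For compound 2 the value of > 100000 nM is a limit of this assay rather than a number, so compound 2 only shows (the limit of > 100000 nM in this assay, at which 1 of the 2 values shown sits). Going by the values given here, the one measured step, an at least 2.3-fold higher number from compound 1 to compound 2 (0.37 log units; beyond the scatter), concerns a change on the aromatic ring and says nothing about the ester end of the shared core.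

Compound 3, `C=C(C)[C@@H]1CC=C(Cn2cc(COc3cccc(C4NC(=O)NC(C)=C4C(C)=O)c3)nn2)CC1`, differs from compound 1 by methyl in place of ethoxy on a carbonyl carbon. Among the compounds with values here, no measured step touches this part of the molecule, so there is no basis for expecting a shift in either direction beyond the scatter. Compound 3 is therefore estimated at 42000 nM, with a range from 14000 nM to 120000 nM. That estimate means a 1.0-fold lower number from compound 1 to compound 3 (0.01 log units; within the scatter), essentially no change from compound 1, while the closeness of compound 1 to the limit leaves a real chance that only a limit is reported.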

Compound 3, concentration for total growth inhibition: 43000 nM
Estimate against measurement, compound 3: 1.0-fold (0.01 log units) below; the range from low to high includes it.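

Up to this point, the only measured step lay on the aromatic ring, so nothing was known about the ethoxycarbonyl group of the shared core. In this assay, replacing that group with acetyl gives a 1.0-fold higher number from compound 1 to compound 3 (0.01 log units; within the scatter), so ethoxy and methyl on this carbonyl carbon cannot be told apart in these two compounds. Compound 2 remains a limit and not a number, which restricts what the series can show at its weak end: the limit of > 100000 nM in this assay, at which 1 of the 3 values shown sits.

From the compounds shown here alone, the carbonyl is present in both compound 1 and compound 3, so its own contribution remains open, as does the effect of a carboxylic acid, an amide or a longer chain such as butoxy on this carbon. Going by these compounds, it is also open whether methoxy on the aromatic ring would have the same effect in the acetyl series.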